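The compounds below may be only part of what the source reports. "The series", "measured", "known", "first", "only" and "open" are said of these compounds alone.

Working notes on the series, read in a functional assay on SK-HEP1 cells (Homo sapiens) for antiproliferative activity, read by sulforhodamine B assay, with a stated time of 72 h; on this read-out higher numbers stand for weaker inhibition and lower numbers for stronger inhibition. Compound 1 (`CCCCS(=O)(=O)Nc1cc(-c2ccc3ncnc(NCCN(C)C)c3c2)cnc1OC`) gives 280 nM, compound 2 (`CCCCS(=O)(=O)Nc1cc(-c2ccc3ncnc(NCc4ccncc4)c3c2)cnc1OC`) gives 8980 nM, and compound 3 (`COc1ncc(-c2ccc3ncnc(NCCCN(C)C)c3c2)cc1NS(=O)(=O)c1ccc(F)cc1F`) gives 4680 nM. Compound 3 cannot be told apart from compound 2, as their gap lies within the scatter, while its gap to compound 1 lies beyond the scatter, with compound 1 the stronger.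

The next comparison is compound 4 (`CCCCS(=O)(=O)Nc1cc(-c2ccc3ncnc(NCCCN(C)C)c3c2)cnc1OC`), with butyl in place of 2,4-difluorophenyl on a sulfonyl sulfur. The rest of compound 3 stays unchanged.

Within the data shown here, no measured step changes this sulfonyl group. Among the measured compounds shown here, the only measured step, a 32-fold higher number from compound 1 to compound 2 (1.51 log units; beyond the scatter), is large but concerns a different exchange, pyridin-4-yl in place of (dimethylamino)methyl. It bears only indirectly, showing that two compounds sharing butyl can still lie far apart. For the measured compounds named here, compound 1, the one measured butyl compound with a dimethylamino end, at 280 nM points toward a lower number, but its chain is not that of compound 4. The expected step is moderate and toward stronger inhibition, a 4.7-fold lower number from compound 3 to compound 4 (0.67 log units; beyond the scatter), with wide uncertainty. For compound 4 the estimated value is 1000 nM, with an expected range of 250 nM to 4500 nM.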

Compound 4, half-maximal inhibitory concentration: 860 nM
Compound 4: the middle estimate sits 1.2-fold (0.07 log units) above what was measured; measured number inside the range.
By their numbers in this assay, from the lowest: compound 1; then compound 4; then compounds 3 and 2 (each within the scatter of the next).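

Notes on this assay: this is the first direct reading of the sulfonyl group, and with the rest of the structure held, butyl in place of 2,4-difluorophenyl gives a 5.4-fold lower number from compound 3 to compound 4 (0.74 log units; beyond the scatter) on this single pair. With butyl fixed on the sulfonyl sulfur, the new compound also places the chain end more precisely: (dimethylamino)methyl in place of dimethylamino on the saturated chain carbon gives a 3.1-fold higher number from compound 1 to compound 4 (0.49 log units; beyond the scatter) and 2-(dimethylamino)ethyl in place of pyridin-4-yl gives a 10-fold lower number from compound 2 to compound 4 (1.02 log units; beyond the scatter), so the dimethylamino chain of compound 4 stays well clear of the pyridin-4-yl compound yet does not reach the shorter-chain compound. Nothing at hand accounts for the size or direction of any of these steps.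

Open, as far as these compounds go, is whether the butyl advantage holds on other chain ends, since the sulfonyl exchange is read on one chain only. Also open, from the compounds shown here alone, is how a methyl, a cyclopropyl or an unsubstituted phenyl on the sulfonyl sulfur would read, and how a morpholine or a piperidine would read at the end of the chain.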